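Fluorine on the acetamido group: expected tolerance

The compounds below may be only part of what the source reports. "The series", "measured", "known", "first", "only" and "open" are said of these compounds alone.

The shared core carries an acylamino group and an amide linking to a varied substituent. In an ADME assay on MDCK cells (Canis lupus familiaris) for cytotoxicity, read by cytopathic effect, with a stated time of 48 h (a lower number here means that less compound is tolerated, a higher number that more compound is tolerated), compound 1 `CCC(=O)Nc1cc(C(=O)Nc2cccc(SC)c2)ccc1OC` gives 324 uM. Compound 2 `CCC(=O)Nc1cc(C(=O)NC2CCCCC2)ccc1OC` gives 510 uM in this assay. The step of a 1.6-fold higher number from compound 1 to compound 2 (0.20 log units; within the scatter) lies within the scatter. Compound 3 `COc1ccc(C(=O)Nc2ccccc2)cc1NC(C)=O` stands at the limit of the assay: in this assay compound 3 gives > 703 uM, which is a limit and not a number (the limit of > 703 uM in this assay, at which 1 of the 3 values shown sits).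

Compound 4 `COc1ccc(C(=O)Nc2ccccc2)cc1NC(=O)C(C)F` differs from compound 3 by 1-fluoroethyl in place of methyl on a carbonyl carbon. For the measured compounds named here, no measured step touches this carbonyl carbon; the only measured step, a 1.6-fold higher number from compound 1 to compound 2 (0.20 log units; within the scatter), concerns the group on the amide-type nitrogen and was within the scatter. There is no basis for a step beyond the scatter in this assay, so the expected step of a number no higher from compound 3 to compound 4 (the limit leaves the size open) is none beyond the scatter. Compound 4 is estimated at 700 uM, with a range from 350 uM to 1400 uM, and a limit rather than a number is the likelier outcome.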

Compound 4, half-maximal toxic concentration: > 632 uM
Compound 4: only a limit was reported; the forecaster's own chance of this, stated with the estimate: 60%; the middle value does not contradict the limit.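

In this assay compound 4 gives > 632 uM, a limit and not a number. For the compounds shown here, compound 3 also stands at a limit, and no step between compound 3 and compound 4 can be read. Going by these compounds, whether 1-fluoroethyl in place of methyl on a carbonyl carbon changes tolerance remains open.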